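The source may report more compounds than this note shows. Statements on the series, on what has been measured and on what is new or still open speak of the compounds shown alone.

Working notes on the series. Compound 2 `Cc1nc(S(C)(=O)=O)ccc1Oc1ncnc(OC2CCN(C(=O)OC(C)F)CC2)c1F` gives 65.5 nM in a functional assay on isolated protein for inhibition of Glucose-dependent insulinotropic receptor (Homo sapiens), read by HTRF and cAMP accumulation (a higher number here means that more compound is needed for the effect, a lower number that less compound is needed), the lowest of the three numbers, though compound 1 `Cc1nc(S(C)(=O)=O)ccc1Oc1ncnc(OC2CCN(C(=O)OC(C)(C)C#N)CC2)c1F` at 92.9 nM sits within the scatter of it, as a 1.4-fold lower number from compound 1 to compound 2 (0.15 log units; within the scatter) shows. Compound 3 `Cc1nc(S(C)(=O)=O)ccc1Oc1ncnc(OC2CCN(C(=O)OC3COC3)CC2)c1F` gives 326 nM in this assay, a modest step away: a 5.0-fold higher number from compound 2 to compound 3 (0.70 log units; beyond the scatter). Compound 4 `Cc1nc(S(C)(=O)=O)ccc1Oc1ncnc(OC2CCN(C(=O)OC3(C(F)(F)F)CCC3)CC2)c1F` is not yet measured. The change from compound 2 is 1-(trifluoromethyl)cyclobutyl in place of 1-fluoroethyl on an oxygen next to a carbonyl group. Among the compounds with values here, the steps that bear on it are a 1.4-fold lower number from compound 1 to compound 2 (0.15 log units; within the scatter), a small branched-for-branched exchange, and a 5.0-fold higher number from compound 2 to compound 3 (0.70 log units; beyond the scatter), where a four-membered ring replaced the 1-fluoroethyl group; the entering group here is also a four-membered ring but of carbon only with a trifluoromethyl group. A modest upward step is expected, a 2.0-fold higher number from compound 2 to compound 4 (0.30 log units; within the scatter), so compound 4 is estimated at 130 nM with a range of 40 nM to 420 nM.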

Compound 4, half-maximal effective concentration: 14.3 nM
The estimate for compound 4 lay 9.1-fold (0.96 log units) above the measured number; measured number below the stated range.
By their numbers in this assay, from the lowest: compound 4; then compounds 2 and 1 (each within the scatter of the next); then compound 3.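

Within the data shown here, at this place, on an oxygen next to a carbonyl group, the larger 1-(trifluoromethyl)cyclobutyl gives the lowest number so far in this assay, with a 4.6-fold lower number from compound 2 to compound 4 (0.66 log units; beyond the scatter), a 6.5-fold lower number from compound 1 to compound 4 (0.81 log units; beyond the scatter) and a 23-fold lower number from compound 3 to compound 4 (1.36 log units; beyond the scatter). A four-membered ring does not in itself raise the number: compound 3 and compound 4 both carry one, yet they stand at opposite ends of the series. Nothing available explains this result. The compounds shown do not separate the contribution of the trifluoromethyl group from that of the carbon-only ring. Plain cyclobutyl or tert-butyl at this place would address that question.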